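Methyl to Methoxy on a Weakly Active Scaffold

The source may hold more compounds than are shown below. What is called first, only, known or untested is meant among the compounds shown, and "the series" means these compounds.

Compound 1, `CCOC(=O)C1=Cc2ccccc2OC1(OCc1cn(CC(=O)Nc2ccc(C)cc2)nn1)C(F)(F)F`: in a functional assay on DU-145 cells (Homo sapiens) for inhibition, read by MTT assay, with a stated time of 24 h (a higher number here means a weaker inhibitor, a lower number a stronger inhibitor), compound 1 gives > 150000 nM, which is a limit of the assay and not a number.
Compound 2, `Cc1ccc(-c2cc(COC3(C(F)(F)F)Oc4ccccc4C=C3C(=O)O)on2)cc1`: in this assay compound 2 gives 41400 nM.

Within the data shown here, compound 2 thus holds the only measured number here, and the other value is a limit. Compound 3, `COc1ccc(-c2cc(COC3(C(F)(F)F)Oc4ccccc4C=C3C(=O)O)on2)cc1`, differs from compound 2 by methoxy in place of methyl on an aromatic carbon. Among the measured compounds shown here, no measured pair shows this change, so the step from compound 2 to compound 3 is expected to be a 1.0-fold lower number from compound 2 to compound 3 (0.01 log units; within the scatter), nothing beyond the usual scatter. Compound 3 is therefore estimated at 40000 nM, with a range from 15000 nM to 110000 nM.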

Compound 3, half-maximal inhibitory concentration: 42000 nM
Estimate against measurement, compound 3: 1.1-fold (0.02 log units) below; low and high end bracket the measured number.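

Going from 4-methylphenyl to 4-methoxyphenyl gives a 1.0-fold higher number from compound 2 to compound 3 (0.01 log units; within the scatter) in this assay. Among these compounds, this is the first step that can be read at this place, para to a large group, and it shows that compound 2 and compound 3 cannot be told apart, even though methoxy brings one more heavy atom than methyl. Nothing shown here offers a reason for this result.

One swap cannot speak for other groups at this place. Going by these compounds, what an amine, a hydroxyl group or a longer chain such as butyl would give remains open.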